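Methyl Steps on a Quinoxaline Dioxide Nitrile Series

The compounds below may be only part of what the source reports. "The series", "measured", "known", "first", "only" and "open" are said of these compounds alone.

Measured compounds:
compound 1 `N#Cc1c(-c2ccco2)[n+]([O-])c2ccccc2[n+]1[O-]` gives 0.582
compound 2 `Cc1ccc2c(c1)[n+]([O-])c(C#N)c(-c1ccco1)[n+]2[O-]` gives 0.845
compound 3 `Cc1ccc(-c2c(C#N)[n+]([O-])c3cc(C)ccc3[n+]2[O-])cc1` gives 2.33

The three compounds were measured in a physicochemical assay for lipophilicity, measured as octanol-water partition; a lower number here means a more polar compound, a higher number a more lipophilic compound. From compound 1 to compound 2 the change is methyl in place of hydrogen on an aromatic carbon, and it gives a number 0.26 log units higher from compound 1 to compound 2 (within the scatter). From compound 2 to compound 3 the change is a different one and it gives a number 1.49 log units higher from compound 2 to compound 3 (beyond the scatter), leaving compound 3 with the highest number of the three. The difference between the cores of compound 1 and compound 3 is not broken down here.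

Compound 4 `Cc1ccc(-c2c(C#N)[n+]([O-])c3cc(C)c(C)cc3[n+]2[O-])cc1` has not yet been measured. It differs from compound 3 by methyl in place of hydrogen on an aromatic carbon; this is the same kind of change as that from compound 1 to compound 2, except that here the place is ortho to a methyl group (1 heavy atom). Because the earlier step was a number 0.26 log units higher from compound 1 to compound 2 (within the scatter), a step of about a number 0.42 log units higher from compound 3 to compound 4 (beyond the scatter) is expected in this assay. Compound 4 is therefore estimated at 2.75, with a likely range from 2.45 to 3.05.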

Compound 4, partition coefficient: 2.57
Estimate against measurement, compound 4: 0.18 log units above; low and high end bracket the measured number.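

In this assay the methyl step on the core of compound 3 gives a number 0.24 log units higher from compound 3 to compound 4 (within the scatter) and the same kind of change on the core of compound 1 gives a number 0.26 log units higher from compound 1 to compound 2 (within the scatter) so on both cores this replacement stays within the usual scatter. Within the data shown here, this agreement rests on only two pairs, and it establishes no real methyl increment on either core, nor does it show whether being ortho to a methyl group matters. No evidence bearing on this result is available.

From the compounds shown here alone, whether an amine or a carboxylic acid on this aromatic carbon would give a step beyond the scatter remains open. So does the effect of a longer chain at that place on the number.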